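Third methoxy on the aryl ring of compound 2

This account rests on a few compounds, and the source may have more. Where it says the series, first, only, none or still open, it means among the compounds named here.

Measured so far in an ADME assay on Vero cells (Chlorocebus sabaeus) for cytotoxicity, read by sulforhodamine B assay, with a stated time of 48 h; a lower number here means that less compound is tolerated, a higher number that more compound is tolerated:
compound 1 `COc1cc(/C(Cl)=C/C=C(\C#N)C(=O)c2c[nH]c3ccccc23)cc(OC)c1OC`: 54200 nM
compound 2 `COc1ccc2[nH]cc(C(=O)/C(C#N)=C/C=C(\Cl)c3ccc(OC)c(OC)c3)c2c1`: "not determined" (no result reported)
compound 3 `COc1ccc(/C(Cl)=C/C=C(\C#N)C(=O)c2c[nH]c3ccc(OC)cc23)cc1`: "not determined" (no result reported)

Compound 2 has no number in this assay, and neither has compound 3; only compound 1 provides a figure. Compound 4 `COc1ccc2[nH]cc(C(=O)/C(C#N)=C/C=C(\Cl)c3cc(OC)c(OC)c(OC)c3)c2c1` arises from compound 2 through (methoxy in place of hydrogen on an aromatic carbon). For the measured compounds named here, no measured pair shows this change, so no step size can be taken from the data. Compound 4 carries the same three methoxy groups on the aryl ring as compound 1, which tolerated a high concentration, and a methoxy on the core as compound 2. For compound 4 the expected result is therefore a value near that of compound 1, estimated at 50000 nM, within 15000 nM to 150000 nM, with a real chance that only a limit is reported.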

Compound 4, concentration lethal to 50% of the cells: 45200 nM
Beside the measured number, compound 4's estimate is 1.1-fold (0.04 log units) above it; low and high end bracket the measured number.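

In this assay, for the compounds shown here, the only step that can be read is the added methoxy on the core, a 1.2-fold lower number from compound 1 to compound 4 (0.08 log units; within the scatter) and so, with three methoxy groups on the aryl ring, this change stays within the scatter. Compound 2 has no number, and its step to compound 4 cannot be read. Nothing at hand speaks to the reason for this result. On these data alone, whether an amine or a carboxylic acid in place of that methoxy on the core would shift the number in this assay stays open. As far as these compounds go, the effect of the third methoxy on the aryl ring also remains open.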